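Swapping the azole on the amide arm of compound 2

A few compounds are considered here, and "the series" means these few. Any claim that something is new, unique, unknown or untested is made for them only; others in the source may bear on it.

Compound 2 `CCOc1ncc(-c2nc(C(F)(F)F)sc2N2CCN(C(=O)Cn3nc(C)cc3C)[C@H](C)C2)cn1` gives 60 nM in an assay on blood for inhibition of C-X-C chemokine receptor type 3 (Homo sapiens), with a stated time of 30 min (on this read-out lower numbers stand for stronger inhibition and higher numbers for weaker inhibition), the highest of the two numbers at hand, with compound 1 `CCOc1ncc(-c2nc(C(F)(F)F)sc2N2CCN(C(=O)Cn3cnc4cccnc43)[C@H](C)C2)cn1` nearest at 48 nM. Among the compounds with values here, the only measured step, a 1.3-fold higher number from compound 1 to compound 2 (0.10 log units; within the scatter), alters the same position that is in question here. Compound 3 `CCOc1ncc(-c2nc(C(F)(F)F)sc2N2CCN(C(=O)Cn3cnc(C(F)(F)F)n3)[C@H](C)C2)cn1` differs from compound 2 by 3-(trifluoromethyl)-1H-1,2,4-triazol-1-yl in place of 3,5-dimethyl-1H-pyrazol-1-yl on a saturated chain carbon bound to a carbonyl carbon. Within the data shown here, only the step from compound 1 to compound 2 bears on this exchange, and it stayed within the scatter, so a further replacement of the azole at this position is expected to change the number in this assay by little if anything; nothing measured so far would support a larger shift in either direction. Compound 3 is therefore estimated at 70 nM, with a range from 30 nM to 170 nM. The expected step of a 1.2-fold higher number from compound 2 to compound 3 (0.07 log units; within the scatter) is accordingly small.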

Compound 3, half-maximal inhibitory concentration: 524 nM
For compound 3 the middle estimate is 7.5-fold (0.87 log units) below the measured one; the measured number lies above the stated range.
By their numbers in this assay, from the lowest: compounds 1 and 2 (each within the scatter of the next); then compound 3.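

In this assay the saturated chain carbon bound to a carbonyl carbon turns out not to tolerate every azole: 3-(trifluoromethyl)-1H-1,2,4-triazol-1-yl in place of 3,5-dimethyl-1H-pyrazol-1-yl gives an 8.7-fold higher number from compound 2 to compound 3 (0.94 log units; beyond the scatter). Against the group carried by compound 1, the same entering group gives an 11-fold higher number from compound 1 to compound 3 (1.04 log units; beyond the scatter), so the two earlier groups, within the scatter of each other, both stand apart from this one. Nothing at hand gives a reason for this difference.

Compound 3 differs from compound 2 in the ring nitrogen count and in its substituents at once, so the compounds shown cannot say which of these changes carries the step. Going by these compounds, whether a methyl-substituted triazole or a trifluoromethyl-substituted pyrazole on the same carbon would stay close to compound 2 or to compound 3 remains open.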